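Moving the acetamidomethyl group around the phenyl ring

This account rests on a few compounds, and the source may have more. Where it says the series, first, only, none or still open, it means among the compounds named here.

Going by the values given here, in a functional assay on blood for antagonist activity at thromboxane A2 receptor (Homo sapiens) (on this read-out higher numbers stand for weaker binding and lower numbers for tighter binding), compound 2 `CS(=O)(=O)Nc1cccc(-c2ccc(COC3CC[C@H](N4CCCCCC4)[C@H]3OC/C=C\CCC(=O)O)cc2)c1` gives 12.6 nM, the lowest of the two numbers so far, though its nearest neighbour, compound 1 `CC(=O)NCc1ccccc1-c1ccc(COC2CC[C@H](N3CCCCCC3)[C@H]2OC/C=C\CCC(=O)O)cc1`, which gives 25.1 nM, sits only a 2.0-fold lower number from compound 1 to compound 2 (0.30 log units; within the scatter) away, a gap inside the usual scatter. Compound 3 `CC(=O)NCc1ccc(-c2ccc(COC3CC[C@H](N4CCCCCC4)[C@H]3OC/C=C\CCC(=O)O)cc2)cc1` has not yet been measured; the change from compound 2 is 4-(acetamidomethyl)phenyl in place of 3-(methanesulfonamido)phenyl on an aromatic carbon, with the new group on an aromatic carbon of a six-membered aromatic ring of carbon only, para to a large group. Among the compounds with values here, the one measured step that bears on it is the exchange of the 2-(acetamidomethyl)phenyl of compound 1 for the 3-(methanesulfonamido)phenyl of compound 2, which moved the number by a 2.0-fold lower number from compound 1 to compound 2 (0.30 log units; within the scatter), within the scatter. Compound 3 returns to an acetamidomethyl group, so its number is expected to land near those of compound 1 and compound 2, a shift of a 1.6-fold higher number from compound 2 to compound 3 (0.20 log units; within the scatter) at most. The estimate for compound 3 in this assay is 20 nM, with a range from 6 nM to 63 nM.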

Compound 3, dissociation constant: 2.51 nM
Compound 3: middle estimate off by 8.0-fold (0.90 log units), on the high side; the measured number lies below the stated range.
By their numbers in this assay, from the lowest: compound 3; then compounds 2 and 1 (each within the scatter of the next).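

Keeping the acetamidomethyl group but changing where it sits on the phenyl ring gives a 10-fold lower number from compound 1 to compound 3 (1.00 log units; beyond the scatter) in this assay, so the position of this group on the ring matters, something the earlier pair, whose gap lay within the scatter, could not show. The exchange of 3-(methanesulfonamido)phenyl for 4-(acetamidomethyl)phenyl gives a 5.0-fold lower number from compound 2 to compound 3 (0.70 log units; beyond the scatter), but this step alters both the group and where it sits, so it cannot separate the two effects. No supporting evidence is available to explain either step.

Going by these compounds, it remains open whether the lower number depends on the acetamidomethyl group itself or would also appear with another group at this place. On these data alone, how a simple amine or a carboxylic acid there would compare is unknown.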